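From fluoro to methoxy on an aromatic carbon

This account rests on a few compounds, and the source may have more. Where it says the series, first, only, none or still open, it means among the compounds named here.

Values in a functional assay on a cell-free system (Platelet, plasma, Homo sapiens) for inhibition; a lower number here means a stronger inhibitor, a higher number a weaker inhibitor:
- compound 1 `Cc1ccc(N(CCN2CCC(OCC(=O)O)CC2)C(=O)c2ccc(Cl)cc2)cc1`: 690 nM
- compound 2 `Cc1ccc(N(CCN2CCC(OCC(=O)O)CC2)C(=O)c2ccc(C(F)(F)F)cc2)cc1`: > 10000 nM (a limit of the assay)
- compound 3 `Cc1ccc(N(CCN2CCC(OCC(=O)O)CC2)C(=O)c2cccc(F)c2)cc1`: 160 nM

Within the data shown here, compound 3 holds the lowest number so far, the measured step being a 4.3-fold lower number from compound 1 to compound 3 (0.63 log units; beyond the scatter). Compound 4 `COc1cccc(C(=O)N(CCN2CCC(OCC(=O)O)CC2)c2ccc(C)cc2)c1` carries methoxy in place of fluoro on an aromatic carbon, meta to a large group: methoxy in place of fluoro on an aromatic carbon. Among the measured compounds shown here, no measured step makes this exact exchange. The closest steps also alter a substituent on this aromatic ring: an at least 14-fold higher number from compound 1 to compound 2 (1.16 log units; beyond the scatter) and an at least 62-fold lower number from compound 2 to compound 3 (1.79 log units; beyond the scatter). Since these range from modest to large, a modest rise in this assay is expected, though with wide uncertainty. The expected change is a 1.9-fold higher number from compound 3 to compound 4 (0.27 log units; within the scatter). For compound 4 the estimated value is 300 nM, with an expected range of 70 nM to 1500 nM.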

Compound 4, half-maximal inhibitory concentration: 32 nM
Compound 4: the middle estimate sits 9.4-fold (0.97 log units) above what was measured; the measured number lies below the stated range.
By their numbers in this assay, from the lowest: compound 4; then compound 3; then compound 1. At a limit, above all of these: compound 2.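

Methoxy in place of fluoro gives a 5.0-fold lower number from compound 3 to compound 4 (0.70 log units; beyond the scatter) in this assay, so the fluoro of compound 3 is not the best group seen at this place on the ring. Exchanging 4-chlorophenyl for 3-methoxyphenyl gives a 22-fold lower number from compound 1 to compound 4 (1.33 log units; beyond the scatter), a step that alters both the group and its place. The step from the 4-(trifluoromethyl)phenyl compound reads an at least 310-fold lower number from compound 2 to compound 4 (2.49 log units; beyond the scatter), its size resting on a limit of the assay: the limit of > 10000 nM in this assay, at which 1 of the 4 values shown sits.

Going by these compounds, how ethoxy, hydroxyl or an amine would read at this place remains open. Also open, on these data alone, is how methoxy itself would read at the ring carbon that carries chloro in compound 1.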